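Swapping 4-methylphenyl for 2-chlorophenyl on a saturated ring carbon

The compounds below may be only part of what the source reports. "The series", "measured", "known", "first", "only" and "open" are said of these compounds alone.

Of the compounds shown here, three have been measured so far in an ADME assay on MT4 cells (Homo sapiens) for cytotoxicity, read by MTT assay, with a stated time of 96 h; a lower number here means that less compound is tolerated, a higher number that more compound is tolerated. Compound 1 (`NS(=O)(=O)c1ccc(N2N=C(c3ccccc3)CC2c2ccccc2Cl)cc1`) gives 44000 nM, compound 2 (`Cc1cccc(C2CC(c3ccc(Oc4ccccc4)cc3)=NN2c2ccc(S(N)(=O)=O)cc2)c1`) gives 35000 nM, and compound 3 (`Cc1ccc(C2CC(c3ccc(Oc4ccccc4)cc3)=NN2c2ccc(S(N)(=O)=O)cc2)cc1`) gives 7200 nM, the lowest of the three numbers.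

Compound 4 (`NS(=O)(=O)c1ccc(N2N=C(c3ccc(Oc4ccccc4)cc3)CC2c2ccccc2Cl)cc1`) has not yet been measured. It departs from compound 3 in one place, where 2-chlorophenyl stands in place of 4-methylphenyl on a saturated ring carbon, next to the ring nitrogen: 2-chlorophenyl in place of 4-methylphenyl on a saturated ring carbon.

Within the data shown here, one measured step bears directly on this place: a 4.9-fold lower number from compound 2 to compound 3 (0.69 log units; beyond the scatter). It is modest but beyond the scatter, and it shows that a change in this group can shift the number in this assay. Among the measured compounds shown here, no measured step brings 2-chlorophenyl into the rest of compound 3. Compound 1 carries that group and gives 44000 nM, but the remainder of compound 1 differs from compound 4, so it offers only indirect guidance.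

A rise of about the same size as the measured step or smaller is therefore expected, estimated as a 2.8-fold higher number from compound 3 to compound 4 (0.44 log units; beyond the scatter). For compound 4 the estimated value is 20000 nM, with an expected range of 7000 nM to 52000 nM.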

Compound 4, half-maximal cytotoxic concentration: 40000 nM
The estimate for compound 4 lay 2.0-fold (0.30 log units) below the measured number; the range from low to high includes it.
By their numbers in this assay, from the lowest: compound 3; then compounds 2, 4 and 1 (each within the scatter of the next).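

In this assay, 2-chlorophenyl in place of 4-methylphenyl on the saturated ring carbon gives a 5.6-fold higher number from compound 3 to compound 4 (0.74 log units; beyond the scatter), whereas 2-chlorophenyl in place of 3-methylphenyl at the same carbon gives a 1.1-fold higher number from compound 2 to compound 4 (0.06 log units; within the scatter), so among the three groups seen here with the phenoxy-bearing core, only 4-methylphenyl stands apart. The phenoxy group, for its part, gives a 1.1-fold lower number from compound 1 to compound 4 (0.04 log units; within the scatter) when it stands in place of hydrogen on an aromatic carbon, so with 2-chlorophenyl on the saturated ring carbon it leaves the number unmoved, and the low number of compound 3 cannot be read as a general feature of phenoxy-bearing compounds. Nothing in the available data accounts for the separate standing of 4-methylphenyl.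

It remains open whether phenoxy would be equally silent alongside 4-methylphenyl, since the compounds shown offer no such pair. Going by these compounds, it is also open whether the low number belongs to the methyl group itself or would return with another group in its place, such as 4-chlorophenyl, 4-methoxyphenyl or 4-aminophenyl.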